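A few compounds are considered here, and "the series" means these few. Any claim that something is new, unique, unknown or untested is made for them only; others in the source may bear on it.

The measured compounds:
compound 1, `COc1cc(OC)nc(N2C(=O)CSC2c2c(F)cccc2F)n1`, in an ADME assay on TZM cells (Homo sapiens) for cytotoxicity, read by MTT assay, with a stated time of 48 h (a lower number here means that less compound is tolerated, a higher number that more compound is tolerated), gives 77500 nM;
compound 2, `O=C1CSC(c2c(F)cccc2Cl)N1c1ccccn1`, gives 153000 nM;
compound 3, `O=C1CSC(c2c(Cl)cccc2Cl)N1c1ccccn1`, gives 149000 nM.

Compound 1 carries a core different from that of compounds 2 and 3; the difference between the two cores is not broken down here. In this assay the values of compound 1, compound 2 and compound 3 all lie within the usual scatter of one another. Compounds 2 and 3 share a core and differ in a single place: chloro in place of fluoro on an aromatic carbon. That change gave a 1.0-fold lower number from compound 2 to compound 3 (0.01 log units; within the scatter).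

Compound 4, `COc1cc(OC)nc(N2C(=O)CSC2c2c(F)cccc2Cl)n1`, is not yet measured. It stands to compound 1 as compound 3 stands to compound 2: chloro in place of fluoro on an aromatic carbon. The two changes are of the same kind but not the same: in compound 1 the place is meta to a fluoro group, whereas in compound 2 it is meta to a chloro group. The earlier step, a 1.0-fold lower number from compound 2 to compound 3 (0.01 log units; within the scatter), lay within the scatter and is the basis of the expectation. The estimated step for compound 4 is a 1.0-fold higher number from compound 1 to compound 4 (0.00 log units; within the scatter). Compound 4 is therefore expected at 78000 nM in this assay, between 40000 nM and 155000 nM.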

Compound 4, half-maximal cytotoxic concentration: 98200 nM
Beside the measured number, compound 4's estimate is 1.3-fold (0.10 log units) below it, and the stated range covers the measured number.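

In this assay, chloro in place of fluoro on an aromatic carbon gave a 1.3-fold higher number from compound 1 to compound 4 (0.10 log units; within the scatter), and this step does not differ from the one seen earlier on the other core: the same change on two cores in this assay, a 1.0-fold lower number (0.01 log units; within the scatter) from compound 2 to compound 3 and a 1.3-fold higher number (0.10 log units; within the scatter) from compound 1 to compound 4, 1.3-fold (0.11 log units) apart, within the scatter of two such steps

This shows that on both cores the change stayed within the scatter, so in these two pairs the core made no difference that can be told apart from the scatter. Within the data shown here, it does not show that the change would stay this small on any further core, since it rests on only two pairs in a single assay, and in those pairs the place is meta to a fluoro group in one and meta to a chloro group in the other.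

The compounds shown leave open whether a group other than a halogen at this place, such as a nitrile or an amine, would give a step beyond the scatter. They also leave open what a carboxylic acid or a longer chain elsewhere on either core would do in this assay.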